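From Chloro to Fluoro at the Limit of the Assay

The source may hold more compounds than are shown below. What is called first, only, known or untested is meant among the compounds shown, and "the series" means these compounds.

In a functional assay on MGC-803 cells (Homo sapiens) for antiproliferative activity, read by CCK-8 assay, with a stated time of 72 h (a lower number here means a stronger inhibitor, a higher number a weaker inhibitor), compound 1 `O=C(/C=C/c1ccc(CN2CCc3ccccc32)cc1)NO` has the entry "not determined" (no result reported), so it offers no number for comparison. Compound 2 `Nc1ccccc1NC(=O)c1ccc(COc2ccc(Cl)cc2)cc1` gives > 32000 nM, which is a limit of the assay and not a number. Compound 3 `Nc1ccccc1NC(=O)/C=C/c1ccc(COc2ccccc2)cc1` gives > 32000 nM, which is also a limit. What has been measured so far therefore comes down to the limit of > 32000 nM in this assay, at which 2 of the 3 values shown sit, and compound 2 stands at that limit with no exact value.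

Compound 4 `Nc1ccccc1NC(=O)c1ccc(COc2ccc(F)cc2)cc1` differs from compound 2 at one place, with fluoro in place of chloro on an aromatic carbon, para to a large group (fluoro in place of chloro on an aromatic carbon). For the measured compounds named here, no step between measured compounds is available as a guide. In this assay, the expected size of a number no higher from compound 2 to compound 4 (the limit leaves the size open) is none beyond the scatter, with no direction favoured. This expectation rests on compound 2 at > 32000 nM. Compound 4 is estimated at 32000 nM, with an expected range from 12000 nM to 64000 nM.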

Compound 4, half-maximal inhibitory concentration: 4970 nM
The estimate for compound 4 lay 6.4-fold (0.81 log units) above the measured number; the whole stated range lies above it.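

In this assay, the change from 4-chlorophenoxy to 4-fluorophenoxy yields the only exact number among the compounds shown, with an at least 6.4-fold lower number from compound 2 to compound 4 (0.80 log units; beyond the scatter). Neither group carries a ring, a hydrogen-bond donor, a hydrogen-bond acceptor or a net charge, so this single exchange on an aromatic carbon, para to a large group, is enough to move the result beyond the scatter. The true size of the step stays open, as compound 2 has only a limit: the limit of > 32000 nM in this assay, at which 2 of the 4 values shown sit.

The compounds shown leave open how a methoxy group, a nitrile or a trifluoromethyl group would read at this same place. They also leave open whether fluoro in this place would bring a similar step on another core, such as that of compound 3.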